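Replacing a dimethoxyphenyl arm with furan-2-yl

The compounds below may be only part of what the source reports. "The series", "measured", "known", "first", "only" and "open" are said of these compounds alone.

Measured so far in a functional assay on A549 cells (Homo sapiens) for antiproliferative activity, read by MTT assay, with a stated time of 48 h; a lower number here means a stronger inhibitor, a higher number a weaker inhibitor:
compound 1 `COc1ccc(-c2nc3cccc(-c4cc(OC)c(OC)c(OC)c4)c3o2)cc1OC` gives 2800 nM;
compound 2 `COc1ccc(-c2nc3cccc(-c4cc(OC)c(OC)c(OC)c4)c3o2)cc1F` gives 1800 nM;
compound 3 `COc1cc(-c2cccc3nc(-c4ccc(N)cc4)oc23)cc(OC)c1OC` gives 720 nM.

Compound 1 has the highest number of the three, so it is the weakest inhibitor shown. Compound 4 `COc1cc(-c2cccc3nc(-c4ccco4)oc23)cc(OC)c1OC` differs from it in one place: furan-2-yl in place of 3,4-dimethoxyphenyl on an aromatic carbon. Within the data shown here, no measured step swaps in a five-membered ring, so only loose guidance exists. The step of a 1.6-fold lower number from compound 1 to compound 2 (0.19 log units; within the scatter) changed little, while a 3.9-fold lower number from compound 1 to compound 3 (0.59 log units; beyond the scatter) gave a modest gain, showing this position tolerates change without large swings. Compound 4 is therefore expected to stay close to compound 1, with a step of about a 1.3-fold higher number from compound 1 to compound 4 (0.10 log units; within the scatter). The estimate for compound 4 is 3500 nM, ranging from 1200 nM to 10000 nM.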

Compound 4, half-maximal inhibitory concentration: 10300 nM
Estimate against measurement, compound 4: 2.9-fold (0.47 log units) below; the measured number lies above the stated range.
By their numbers in this assay, from the lowest: compound 3; then compounds 2 and 1 (each within the scatter of the next); then compound 4.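

In this assay, this position proves less forgiving than the earlier compounds suggested: furan-2-yl is the only arm shown that raises the number, with a 3.7-fold higher number from compound 1 to compound 4 (0.57 log units; beyond the scatter). The loss is wider against the other arms, with a 5.7-fold higher number from compound 2 to compound 4 (0.76 log units; beyond the scatter) and a 14-fold higher number from compound 3 to compound 4 (1.16 log units; beyond the scatter), so among these compounds this five-membered ring does not stand in for a substituted phenyl ring. No measurement here accounts for the loss. Going by these compounds, it remains open whether the loss belongs to the furan ring itself or to the absence of a six-membered ring, a question that an unsubstituted phenyl or a thiophen-2-yl arm could help settle.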